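A Larger Amide Substituent on Compound 2

The source may hold more compounds than are shown below. What is called first, only, known or untested is meant among the compounds shown, and "the series" means these compounds.

Compound 1, `Clc1nc(NC2CC2)c2ncn(C3CCCCO3)c2n1`: 11.9%
Compound 2, `C[C@H](NC(=O)CN(c1nc(Cl)nc2c1ncn2C1CCCCO1)C1CC1)C(=O)OCc1ccccc1`: 32.1%

Of the compounds shown here, two have been measured in a functional assay on the whole organism with Mus musculus as the target, with a stated time of 90 min, at a dose of 25 umol/kg by the oral route; on this read-out higher numbers stand for a stronger effect at the one dose given and lower numbers for a weaker effect. Compound 2 stands highest of the two, and compound 1 lies lower than compound 2 by a gap beyond the usual scatter. Compound 3, `O=C(CN(c1nc(Cl)nc2c1ncn2C1CCCCO1)C1CC1)N[C@@H](CCC(=O)OCc1ccccc1)C(=O)OCc1ccccc1`, has not yet been measured. It differs from compound 2 in a single place: (benzyloxycarbonyl)methyl in place of hydrogen on a saturated chain carbon, two bonds along the chain from an amide-type nitrogen and a carbonyl carbon. Among the compounds with values here, no measured pair shows a change of this kind, so the step from compound 2 to compound 3 is expected to be small, possibly within the scatter, and its direction is uncertain: a number 2.1 percentage points lower from compound 2 to compound 3 (within the scatter). Compound 3 is estimated at 30%, with a range from 10% to 55%.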

Compound 3, a percentage reported as activity, at one dose (the size of the read-out at that dose, not a potency): 25.2%
Beside the measured number, compound 3's estimate is 4.8 percentage points above it; the range from low to high includes it.
By their numbers in this assay, from the lowest: compound 1; then compounds 3 and 2 (each within the scatter of the next).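

In this assay, adding (benzyloxycarbonyl)methyl in place of hydrogen on this saturated chain carbon gives a number 6.9 percentage points lower from compound 2 to compound 3 (within the scatter). A group of 11 heavy atoms carrying a six-membered aromatic ring can therefore enter here without the read-out separating the two compounds. No measurement given here bears on why this is so. Within the data shown here, only this one group has been compared at this carbon, so it stays open how a carboxylic acid or an amine in its place would read.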